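The source may report more compounds than this note shows. Statements on the series, on what has been measured and on what is new or still open speak of the compounds shown alone.

Three compounds share one core and differ only in the group carried by the oxygen on the aromatic ring. Compound 1 `CCCCOc1ccc2c(Cl)ccnc2c1` carries a butyl chain there, compound 2 `CCCCCCOc1ccc2c(Cl)ccnc2c1` a hexyl chain and compound 3 `C=CCOc1ccc2c(Cl)ccnc2c1` an allyl group. In a functional assay on RKO cells (Homo sapiens) for cytotoxicity, read by MTT assay, with a stated time of 48 h (a higher number here means a weaker inhibitor, a lower number a stronger inhibitor), compound 1 gives 3050 nM, compound 2 gives 2720 nM and compound 3 gives 2460 nM. The three numbers cannot be told apart: a 1.1-fold lower number from compound 1 to compound 2 (0.05 log units; within the scatter), a 1.2-fold lower number from compound 1 to compound 3 (0.09 log units; within the scatter) and a 1.1-fold lower number from compound 2 to compound 3 (0.04 log units; within the scatter). Compound 3 therefore stands among its two companions with no separation beyond the scatter in either direction.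

Compound 4 `CC(C)Oc1ccc2c(Cl)ccnc2c1` takes the next step, (isopropyl in place of allyl on an oxygen on an aromatic ring). Among the measured compounds shown here, the steps that bear on this are those that already changed the group on the same oxygen, from compound 1 to compound 3 and from compound 2 to compound 3, and both were within the scatter. With a third group of the same size entering at the same place, no step beyond the scatter is expected in this assay in either direction. Compound 4 is therefore estimated at 2600 nM, between 1300 nM and 5200 nM. That estimate means a 1.1-fold higher number from compound 3 to compound 4 (0.02 log units; within the scatter) is expected.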

Compound 4, half-maximal inhibitory concentration: 2690 nM
For compound 4 the middle estimate is 1.0-fold (0.01 log units) below the measured one, and the stated range covers the measured number.
By their numbers in this assay, from the lowest: compounds 3, 4, 2 and 1 (each within the scatter of the next).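

Among the compounds shown here, compound 4 puts a branched group on the oxygen for the first time, and in this assay the exchange of allyl for isopropyl, with the same count of heavy atoms and without the double bond outside aromatic rings, gives a 1.1-fold higher number from compound 3 to compound 4 (0.04 log units; within the scatter) at this position. Set against the two straight chains, the same isopropyl gives a 1.0-fold lower number from compound 2 to compound 4 (0.00 log units; within the scatter) and a 1.1-fold lower number from compound 1 to compound 4 (0.05 log units; within the scatter) so that neither branching, nor the double bond, nor the chain lengths shown separate these four compounds in this assay. No measurement at hand speaks to why the numbers stay together.

The compounds shown leave open whether a group of another kind on this oxygen, such as an aminoethyl chain, a carboxylic acid or a benzyl group, would give a step beyond the scatter in this assay at all. They also leave open whether a chain longer than hexyl, or a hydrogen in place of the whole group, would still fall within the scatter of these four.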